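The compounds below may be only part of what the source reports. "The series", "measured", "known", "first", "only" and "open" are said of these compounds alone.

Working notes on the enaminone series built on the shared core, read in a functional assay on PC-3 cells (Homo sapiens) for antiproliferative activity, read by MTT assay, with a stated time of 48 h; a higher number here means a weaker inhibitor, a lower number a stronger inhibitor.

Compound 2 `COc1cc(-c2nn(-c3ccccc3)cc2C(=O)/C=C\Nc2ccc(F)cc2)cc(OC)c1OC` gives 7700 nM in this assay. Compound 3 `COc1cc(-c2nn(-c3ccccc3)cc2C(=O)/C=C\Nc2ccc(Cl)cc2)cc(OC)c1OC` gives 11200 nM in this assay. For the measured compounds named here, the one paired change measured so far, a 1.5-fold higher number from compound 2 to compound 3 (0.16 log units; within the scatter), stays within the scatter. Compound 1 `O=C(/C=C\Nc1ccc(C(F)(F)F)cc1)c1cn(-c2ccccc2)nc1-c1ccc(Cl)cc1` carries a trifluoromethyl on the anilino ring but also a chlorophenyl where compounds 2 and 3 carry the trimethoxyphenyl. In this assay compound 1 reaches only > 50000 nM, a limit of the assay and not a number (the limit of > 50000 nM in this assay, at which 1 of the 3 values shown sits).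

Of the two numbers shown, compound 3 holds the higher one, yet its gap to compound 2 is within the scatter, so no order between them is claimed; the third value is a limit.

The next step is trifluoromethyl in place of chloro on an aromatic carbon, giving compound 4 `COc1cc(-c2nn(-c3ccccc3)cc2C(=O)/C=C\Nc2ccc(C(F)(F)F)cc2)cc(OC)c1OC`. Going by the values given here, no measured step covers trifluoromethyl against chloro on this ring: compound 1 carries the trifluoromethyl but differs at the second ring as well, so its limit and the number of compound 3 cannot be read as a step. Among the compounds with values here, the only substituent swap on the anilino ring, from compound 2 to compound 3, stayed within the scatter, so no step beyond the scatter is expected in this assay, with a possible drift toward a higher number.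

Compound 4 is estimated at 16000 nM, range 6000 nM to 50000 nM, an expected step of a 1.4-fold higher number from compound 3 to compound 4 (0.15 log units; within the scatter).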

Compound 4, half-maximal inhibitory concentration: > 50000 nM
Compound 4 ended at the assay's limit; the forecaster's own chance of this, stated with the estimate: 20%; middle value at least 3.1-fold (0.49 log units) away from the limit.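

With the 3,4,5-trimethoxyphenyl held in place, this position, para to a large group, now shows a step beyond the scatter in this assay: trifluoromethyl in place of chloro gives an at least 4.4-fold higher number from compound 3 to compound 4 (0.64 log units; beyond the scatter) and trifluoromethyl in place of fluoro gives an at least 6.4-fold higher number from compound 2 to compound 4 (0.81 log units; beyond the scatter). For the compounds shown here, the only earlier swap here, a 1.5-fold higher number from compound 2 to compound 3 (0.16 log units; within the scatter), stayed within the scatter, so trifluoromethyl is the first group at this position to separate from the other two in this pair of comparisons. As far as these compounds go, compound 4 gives > 50000 nM, which is a limit of the assay and not a number, and the full size of both steps stays unknown: the limit of > 50000 nM in this assay, at which 2 of the 4 values shown sit.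

The step between compound 1 and compound 4 cannot be read, which leaves open whether the 3,4,5-trimethoxyphenyl or the 4-chlorophenyl is the better partner for trifluoromethyl. Also open, from the compounds shown here alone, is how a nitrile or an amine at this position would read against the fluoro of compound 2 and the chloro of compound 3.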